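The source may hold more compounds than are shown below. What is called first, only, known or untested is meant among the compounds shown, and "the series" means these compounds.

In a functional assay on Caco-2 cells (Homo sapiens), read by MTT assay, with a stated time of 48 h (on this read-out higher numbers stand for weaker inhibition and lower numbers for stronger inhibition), compound 1 (`CCN(CC)CCCNC(=O)c1ccc(C(CC)(CC)c2ccc(OCC(=O)C(C)(C)C)c(C)c2)n1CC`) gives 1000 nM and compound 2 (`CCOC(=O)CN(C)C(=O)c1ccc(C(CC)(CC)c2ccc(OCC(O)C(C)(C)C)c(C)c2)n1CC`) gives 12200 nM as the higher of the two numbers, a gap beyond the scatter. Compound 3 (`CCn1c(C(=O)NCC(OC)OC)ccc1C(CC)(CC)c1ccc(OCC(O)C(C)(C)C)c(C)c1`) carries (2,2-dimethoxyethyl)amino in place of ((ethoxycarbonyl)methyl)(methyl)amino on a carbonyl carbon. Among the compounds with values here, no pair of measured compounds differs in one place only, so the data offer no direct guide to this change. The expected 1.2-fold lower number from compound 2 to compound 3 (0.09 log units; within the scatter) stays within the scatter in this assay and has no clear direction. The estimate for compound 3 is 10000 nM (range 3000 nM to 30000 nM) and remains to be tested.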

Compound 3, half-maximal inhibitory concentration: > 50000 nM
Compound 3 was reported as a limit; the forecaster's own chance of this, stated with the estimate: 10%; middle value at least 5.0-fold (0.69 log units) away from the limit.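

In this assay compound 3 gives > 50000 nM, which is a limit of the assay and not a number. Putting (2,2-dimethoxyethyl)amino in place of ((ethoxycarbonyl)methyl)(methyl)amino on the carbonyl carbon gives an at least 4.0-fold higher number from compound 2 to compound 3 (0.61 log units; beyond the scatter), so the group at this position does affect the read-out. The size of this step can be given only as a bound: the limit of > 50000 nM in this assay, at which 1 of the 3 values shown sits.

Going by these compounds, what remains open is which part of the change matters: the dimethoxyethyl chain, the amide hydrogen or the departure of the ester. On these data alone, how a morpholine or a carboxylic acid would fare on the same carbonyl carbon also remains open.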